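Trimming the Ring-Nitrogen Substituent of Compound 1

The source may hold more compounds than are shown below. What is called first, only, known or untested is meant among the compounds shown, and "the series" means these compounds.

Compound 1 `O=C(O)c1cc(-c2cccc(COc3ccc4c(=O)n(CC5CC5)sc4c3)c2)ccc1Cl` was tested in an assay on HEK293 cells for positive allosteric modulation of metabotropic glutamate receptor 2 (Rattus norvegicus), read by thallium flux (on this read-out lower numbers stand for an effect already at smaller amounts and higher numbers for an effect only at larger amounts of compound), where compound 1 gives 2480 nM. This is the higher of the two numbers available. The other measured compound, compound 2 `O=C(O)c1cc(F)cc(-c2cccc(COc3ccc4c(c3)CN(C3CCCC3)C4=O)c2)c1`, gives 130 nM in this assay, a value beyond the scatter from that of compound 1; the two compounds differ in several places at once, so the gap cannot be traced to any single change. Compound 3 `O=C(O)c1cc(-c2cccc(COc3ccc4c(=O)n(C5CC5)sc4c3)c2)ccc1Cl` has not been measured. It differs from compound 1 in one place: cyclopropyl in place of cyclopropylmethyl on an aromatic nitrogen. Among the compounds with values here, no measured pair shows a change of this kind, so there is no step to lean on. A small alteration of this sort on the shared core is expected to move the number little, with the step of a 1.1-fold lower number from compound 1 to compound 3 (0.05 log units; within the scatter) expected to stay within the scatter. Compound 3 is therefore expected to give about 2200 nM in this assay, with a range from 800 nM to 6500 nM.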

Compound 3, half-maximal effective concentration: 130 nM
For compound 3 the middle estimate is 17-fold (1.23 log units) above the measured one, and the stated range ends above it.
By their numbers in this assay, from the lowest: compounds 2 and 3 (each within the scatter of the next); then compound 1.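

On the shared core, the group on the aromatic nitrogen next to the ring sulfur proves far from neutral in this assay: cyclopropyl in place of cyclopropylmethyl brings a 19-fold lower number from compound 1 to compound 3 (1.28 log units; beyond the scatter). This large step comes from a small change, 3 heavy atoms against 4, with both groups carrying one three-membered ring of carbon only and neither carrying a hydrogen-bond donor or acceptor. Nothing available explains why the number moves this far.

The compounds shown leave open whether the step belongs to the cyclopropyl ring itself or to the removal of the connecting carbon, as no methyl, ethyl, isopropyl or cyclobutyl group appears on this nitrogen. Going by these compounds, it also remains open whether the same change would carry the same weight on a core with another group in place of the chlorine.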